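Working notes: from compound 2 to compound 3

This account rests on a few compounds, and the source may have more. Where it says the series, first, only, none or still open, it means among the compounds named here.

Compound 1 `CN(C)C(=O)c1cc2cnc(Nc3ccc(NC(=O)C4(C(=O)Nc5cccc(Cl)c5)CC4)cc3)nc2n1C1CCCC1`: 90.7%
Compound 2 `COC(=O)c1cccc(NC(=O)C2(C(=O)Nc3ccc(Nc4ncc5cc(C(=O)N(C)C)n(C6CCCC6)c5n4)cc3)CC2)c1`: 91%

In a functional assay on A549 cells (Homo sapiens) for inhibition, read by CCK-8 assay, with a stated time of 72 h, tested at 10 uM (on this read-out higher numbers stand for more inhibition of growth at the one concentration tested and lower numbers for less inhibition of growth), compound 2 stands at 91%, level with compound 1 at 90.7%. Within the data shown here, the single measured step is a number 0.3 percentage points higher from compound 1 to compound 2 (within the scatter), so the two cannot be ranked.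

The next entry is compound 3 `CN(C)C(=O)c1cc2cnc(Nc3ccc(NC(=O)C4(C(=O)Nc5ccc(C#N)cc5)CC4)cc3)nc2n1C1CCCC1`, not yet measured. The change is 4-cyanophenyl in place of 3-(methoxycarbonyl)phenyl on an amide-type nitrogen. Among the measured compounds shown here, the only step that bears on it is the one above, methoxycarbonyl in place of chloro on an aromatic carbon, and that step stayed within the scatter. For the measured compounds named here, it is thin support: no measured compound carries 4-cyanophenyl, and neither measured pair shows what a different substitution pattern on this aromatic group does. A large change therefore cannot be excluded, although nothing measured points to one.

In this assay, going by the values given here, the expected outcome is a number 3 percentage points lower from compound 2 to compound 3 (within the scatter), with no step expected beyond the scatter. For compound 3 the estimated value is 88%. The expected range runs from 74% to 97%.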

Compound 3, percent growth inhibition at one concentration: 95%
Beside the measured number, compound 3's estimate is 7 percentage points below it; measured number inside the range.
By their numbers in this assay, from the lowest: compounds 1, 2 and 3 (each within the scatter of the next).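

Notes on the group on the amide-type nitrogen: in this assay, 4-cyanophenyl in place of 3-(methoxycarbonyl)phenyl gives a number 4 percentage points higher from compound 2 to compound 3 (within the scatter), and 4-cyanophenyl in place of 3-chlorophenyl gives a number 4.3 percentage points higher from compound 1 to compound 3 (within the scatter). The earlier pair varied only the substituent on a 3-substituted phenyl group, whereas these steps show that a 4-cyanophenyl group on this nitrogen also leaves the read-out within the scatter, so all three compounds stand level and cannot be ranked. No evidence is available that would explain this result or tie it to any feature of the groups exchanged.

The compounds shown leave open whether this nitrogen stays equally permissive with a carboxylic acid or an aminomethyl group on the phenyl ring, or with a longer chain, such as a benzyl or phenethyl group, in place of the directly attached phenyl ring. They also leave open whether compounds that stand level in this assay would separate in a full concentration-response measurement, since a reading at one concentration gives no potency value for any of them.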